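This account rests on a few compounds, and the source may have more. Where it says the series, first, only, none or still open, it means among the compounds named here.

In a functional assay (aorta) for inhibition, with Rattus norvegicus as the target (on this read-out lower numbers stand for stronger inhibition and higher numbers for weaker inhibition), three compounds have been measured so far:

- Compound 1 `CCC(C)(C)/N=C(\NC#N)Nc1ccc(S(=O)(=O)N2CCCCC2)cc1`: > 30 nM, which is a limit of the assay and not a number
- Compound 2 `CC(C)(C)/N=C(\NC#N)Nc1ccc(C#N)cc1`: 530 nM
- Compound 3 `CC(/N=C(\NC#N)Nc1cccc(C#N)c1)C(C)(C)C`: 190 nM

Compound 2 has the higher of the two actual numbers, and the gap down to compound 3 lies beyond the usual scatter. The next compound, compound 4 `CCC(C)(C)/N=C(\NC#N)Nc1ccc(C#N)cc1`, differs from compound 2 in one place: methyl in place of hydrogen on a saturated chain carbon, two bonds along the chain from a double-bonded nitrogen. This turns tert-butyl into 1,1-dimethylpropyl. Among the compounds with values here, no measured pair shows this change, so the expectation in this assay is modest: a small move toward a lower number, within the scatter. The estimated 1.7-fold lower number from compound 2 to compound 4 (0.22 log units; within the scatter) reflects this. For compound 4, the expected value is 320 nM, with an estimated range of 120 nM to 850 nM.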

Compound 4, half-maximal inhibitory concentration: 130 nM
For compound 4 the middle estimate is 2.5-fold (0.39 log units) above the measured one; measured number inside the range.
By their numbers in this assay, from the lowest: compounds 4 and 3 (each within the scatter of the next); then compound 2.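

In this assay one added methyl on the saturated chain carbon gives a 4.1-fold lower number from compound 2 to compound 4 (0.61 log units; beyond the scatter) and so shows that this position responds to even this small change. Within the data shown here, no earlier pair could show this, and the step from tert-butyl to 1,1-dimethylpropyl is not merely tolerated here but goes toward stronger inhibition.

As far as these compounds go, whether a longer chain or an amine at this place would go further stays open. Compound 1 also carries 1,1-dimethylpropyl, but its > 30 nM is a limit of the assay and not a number, so it gives no second reading of this change: the limit of > 30 nM in this assay, at which 1 of the 4 values shown sits.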